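Propanoyl removal on the ring nitrogen and growth inhibition

The compounds below may be only part of what the source reports. "The series", "measured", "known", "first", "only" and "open" are said of these compounds alone.

Compound 2 `CCC(=O)N1c2ccccc2CCC1C(=O)Nc1ccccc1C(F)(F)F` and compound 1 `O=C(Nc1ccccc1C(F)(F)F)C1CCc2ccccc2N1` share one core and differ at a single place: hydrogen in place of propanoyl on a nitrogen on an aromatic ring in a ring. In a functional assay on ACHN cells (Homo sapiens) for cytotoxicity, read by sulforhodamine B assay, with a stated time of 72 h (a lower number here means a stronger inhibitor of growth, a higher number a weaker inhibitor of growth), compound 1 gives 57600 nM. For compound 2 the assay reports only a limit, > 80000 nM, and no number. The step of an at least 1.3-fold lower number from compound 2 to compound 1 (0.14 log units; that floor lies within the scatter) is therefore only a floor, and that floor comes from the limit of > 80000 nM in this assay, at which 1 of the 3 values shown sits; how much further the true step runs is not known.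

Compound 3 `CCC(=O)N1c2ccccc2CCC1C(=O)Nc1cc(C(F)(F)F)cc(C(F)(F)F)c1` keeps the propanoyl on the ring nitrogen but carries a different aryl amide part; how its core differs from the core of compound 2 is not broken down here. In this assay compound 3 gives 7720 nM, the lowest of the two numbers, with compound 1 sitting higher by a gap that lies beyond the scatter.

Compound 4 `O=C(Nc1cc(C(F)(F)F)cc(C(F)(F)F)c1)C1CCc2ccccc2N1` has not been measured. It differs from compound 3 by hydrogen in place of propanoyl on a nitrogen on an aromatic ring in a ring, the same change, at the same place, as that from compound 2 to compound 1. Among the measured compounds shown here, since the only measured instance of this change is a floor whose size lies within the scatter, compound 4 is expected to stay close to compound 3, with an estimated step of a 1.3-fold lower number from compound 3 to compound 4 (0.11 log units; within the scatter). Compound 4 is therefore estimated at 6000 nM in this assay, most likely between 2000 nM and 20000 nM.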

Compound 4, concentration for 50% growth inhibition: 8190 nM
Estimate against measurement, compound 4: 1.4-fold (0.14 log units) below; measured number inside the range.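

In this assay, hydrogen in place of propanoyl on the ring nitrogen gives a 1.1-fold higher number from compound 3 to compound 4 (0.03 log units; within the scatter), so on this core the change leaves no difference that can be told from the scatter. This is the only fully readable instance of the change, and setting it beside the earlier step gives the following picture: the same change on two cores in this assay, an at least 1.3-fold lower number (0.14 log units; that floor lies within the scatter) from compound 2 to compound 1 and a 1.1-fold higher number (0.03 log units; within the scatter) from compound 3 to compound 4; the limit leaves it open whether they differ For compound 2 the assay reports only a limit and no number, > 80000 nM, so the data show no transfer of one step size from core to core and do not rule out a larger step on the core of compound 2: the limit of > 80000 nM in this assay, at which 1 of the 4 values shown sits.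

What the compounds shown leave open is whether the ring nitrogen tolerates other groups in the same way, for instance acetyl, a longer acyl chain such as hexanoyl, or benzoyl, since propanoyl and hydrogen are the only two compared there. Also open, as far as these compounds go, is whether the same indifference to the propanoyl group would hold on cores whose aryl amide part carries a nitrile, an amine or a carboxylic acid in place of trifluoromethyl, and whether it would extend to cells other than those of this single assay.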